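A few compounds are considered here, and "the series" means these few. Any claim that something is new, unique, unknown or untested is made for them only; others in the source may bear on it.

Measured in a functional assay on A549 cells (Homo sapiens) for inhibition, read by MTT assay, with a stated time of 72 h (a higher number here means a weaker inhibitor, a lower number a stronger inhibitor), so far
compound 1 `COc1cc(OC)c(OC)cc1/C=C/C(=O)c1c(OC)cc(O)c(CC=C(C)C)c1O` gives 14400 nM
compound 2 `COc1cc(/C=C/C(=O)c2c(OC)cc(O)c(CC=C(C)C)c2O)cc(OC)c1OC` gives > 50000 nM as a limit
compound 3 `COc1cc(O)c(CC=C(C)C)c(O)c1C(=O)/C=C/c1cccc([N+](=O)[O-])c1` gives 15000 nM

Compound 2 stands at the limit of this assay, with > 50000 nM as its only entry, and this is a limit and not a number. Compound 1 and compound 3 both carry numbers, and these lie within the usual scatter of each other.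

Compound 4 `COc1cc(/C=C/C(=O)c2c(O)cc(O)cc2OC)cc(OC)c1OC` has not yet been measured. It departs from compound 2 in one place (hydrogen in place of 3-methylbut-2-en-1-yl on an aromatic carbon): hydrogen in place of 3-methylbut-2-en-1-yl on an aromatic carbon, ortho to two hydroxy groups and para to a methoxy group. Among the measured compounds shown here, all three measured compounds carry the 3-methylbut-2-en-1-yl group, so none of them shows what its loss does, and no measured pair differs in one place only.

The expectation in this assay is therefore no step beyond the scatter, in either direction, and the reading may again be only a limit. It starts from compound 2 and its limit of > 50000 nM as the sole anchor. The step expected is a number no higher from compound 2 to compound 4 (the limit leaves the size open) as an estimate. For compound 4 the expected value is 50000 nM in this assay with a range from 15000 nM to 100000 nM as estimated.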

Compound 4, half-maximal inhibitory concentration: 28400 nM
For compound 4 the middle estimate is 1.8-fold (0.25 log units) above the measured one; measured number inside the range.
By their numbers in this assay, from the lowest: compounds 1, 3 and 4 (each within the scatter of the next). At a limit, above all of these: compound 2.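

In this assay, hydrogen in place of 3-methylbut-2-en-1-yl on an aromatic carbon, ortho to two hydroxy groups and para to a methoxy group, gives an at least 1.7-fold lower number from compound 2 to compound 4 (0.24 log units; that floor lies within the scatter). Among the compounds shown here, this is the first view of this change, since all the earlier compounds carry the 3-methylbut-2-en-1-yl group: with hydrogen at this position, compound 4 gives a number, 28400 nM, so on this core the group is not needed for a numerical reading in this assay. The true size of the step cannot be given, and it cannot be said to exceed the scatter, because compound 2 has no number, only a limit: the limit of > 50000 nM in this assay, at which 1 of the 4 values shown sits.

What the same exchange does on the cores of compound 1 and compound 3 stays open, as neither has a partner with hydrogen at this position among the compounds shown. Also open, on these data alone, is what a saturated 3-methylbutyl chain, a longer chain, an amine or a carboxylic acid on this aromatic carbon would give in this assay.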